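The source may report more compounds than this note shows. Statements on the series, on what has been measured and on what is new or still open speak of the compounds shown alone.

Values in an assay for displacement of a labelled ligand from protein arginine N-methyltransferase 1 (Homo sapiens), read by scintillation proximity assay, with stated times of 5 min and 8 min, tested at 10 uM (on this read-out lower numbers stand for a weaker effect and higher numbers for a stronger effect at the one concentration tested), for the measured compounds:

compound 1 `CC1(C)C(/C=C/C=C2/N(CCCc3ccccc3)c3ccc(Br)cc3C2(C)C)=[N+](CCCc2ccccc2)c2ccc(Br)cc21` — 101%
compound 2 `CN1/C(=C/C=C/C2=[N+](CCCc3ccccc3)c3ccccc3C2(C)C)C(C)(C)c2ccccc21` — 35%
compound 3 `CCN1/C(=C/C=C/c2sc3cc(Br)ccc3[n+]2CC)Sc2cc(Br)ccc21` — 88%

Compound 2 stands lowest of the three numbers in this assay. Its nearest neighbour is compound 3, whose number lies higher by a margin beyond the scatter, and its furthest is compound 1, higher again by a margin beyond the scatter. Among the measured compounds shown here, no pair among the three differs in only one place, so no single-change step is available to calibrate what follows.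

Compound 4 `CN1/C(=C/C=C/C2=[N+](CCCS(=O)(=O)[O-])c3ccccc3C2(C)C)C(C)(C)c2ccccc21` is the next member to be measured. Relative to compound 2 it carries a group of 4 heavy atoms (3 oxygen, 1 sulfur; no ring) in place of a group of 6 heavy atoms (6 carbon; one six-membered aromatic ring of carbon only), on a saturated chain carbon, three bonds along the chain from a double-bonded nitrogen in a ring. For the measured compounds named here, nothing among the measured compounds shows this change, so the direction of the step in this assay cannot be read from a precedent; the working expectation is no change beyond the scatter, with a lean toward a somewhat lower number rather than a higher one, since compound 2 already sits at the bottom of the series and nothing measured points upward for this exchange.

On that basis compound 4 is expected to give about 22% in this assay, with a range from 0% to 50%. The estimated step is a number 13 percentage points lower from compound 2 to compound 4 (beyond the scatter).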

Compound 4, a percentage reported as inhibition, at one concentration (the size of the read-out at that concentration, not a potency): "not active" (no number reported)
The entry for compound 4 holds no number; there is nothing to compare the estimate with.
By their numbers in this assay, from the lowest: compound 2; then compound 3; then compound 1.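

In this assay, among the compounds shown here, compound 4 is reported as not active, with no number, so no step from compound 2 to compound 4 can be read. The compounds shown leave open how far the exchange of phenyl for the negatively charged group moves the read-out, and whether it does so on other members of the series. No supporting measurement bears on this result.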